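Replacing an Oxadiazole with a Hydroxycyclohexenyl Ring

The source may report more compounds than this note shows. Statements on the series, on what has been measured and on what is new or still open speak of the compounds shown alone.

Compound 1 `C[C@@H](O[C@H]1CN2C(=O)C=C(c3cnn(C)c3)CC2[C@@H]1c1ccc(F)cc1)c1cc(C(F)(F)F)cc(C(F)(F)F)c1` and compound 2 `CCc1noc(C2=CC(=O)N3C[C@H](O[C@H](C)c4cc(C(F)(F)F)cc(C(F)(F)F)c4)[C@@H](c4ccc(F)cc4)C3C2)n1` share a core and differ only on a double-bonded ring carbon, where compound 1 carries 1-methyl-1H-pyrazol-4-yl and compound 2 carries 3-ethyl-1,2,4-oxadiazol-5-yl. In an assay on CHO cells for displacement of a labelled ligand from Substance-P receptor (Homo sapiens) (a higher number here means a weaker inhibitor, a lower number a stronger inhibitor), compound 1 gives 0.13 nM, and in the same setting compound 2 gives 0.4 nM. The step of a 3.1-fold higher number from compound 1 to compound 2 (0.49 log units; beyond the scatter) is the only one measured, and it leaves compound 2 with the highest number of the two. Compound 3 `C[C@@H](O[C@H]1CN2C(=O)C=C(C3=CCC(O)CC3)CC2[C@@H]1c1ccc(F)cc1)c1cc(C(F)(F)F)cc(C(F)(F)F)c1` is not yet measured; it differs from compound 2 by 4-hydroxycyclohex-1-en-1-yl in place of 3-ethyl-1,2,4-oxadiazol-5-yl on a double-bonded ring carbon. Among the measured compounds shown here, the one measured step concerns the same double-bonded ring carbon and was modest, so the group at this place moves this assay by a small amount, though compound 3 brings a non-aromatic ring with a hydrogen-bond donor rather than a five-membered aromatic ring. Compound 3 is therefore expected to show a step of a 1.3-fold higher number from compound 2 to compound 3 (0.10 log units; within the scatter), at most modest and uncertain in direction. The estimate for compound 3 in this assay is 0.5 nM, within a range from 0.15 nM to 2 nM.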

Compound 3, half-maximal inhibitory concentration: 0.18 nM
For compound 3 the middle estimate is 2.8-fold (0.44 log units) above the measured one; low and high end bracket the measured number.
By their numbers in this assay, from the lowest: compounds 1 and 3 (each within the scatter of the next); then compound 2.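

In this assay, an aromatic ring on the double-bonded ring carbon turns out not to be needed for a number at this level: the step of a 1.4-fold higher number from compound 1 to compound 3 (0.14 log units; within the scatter) lies within the scatter, so the non-aromatic 4-hydroxycyclohex-1-en-1-yl cannot be told apart from the five-membered aromatic 1-methyl-1H-pyrazol-4-yl. The step of a 2.2-fold lower number from compound 2 to compound 3 (0.35 log units; beyond the scatter) is modest but beyond the scatter, which shows that two groups of 7 heavy atoms each, 3-ethyl-1,2,4-oxadiazol-5-yl and 4-hydroxycyclohex-1-en-1-yl, remain distinguishable at this place, and among these three compounds 3-ethyl-1,2,4-oxadiazol-5-yl alone stands apart. Nothing available here accounts for these differences.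

Open, on these data alone, is whether the hydroxyl of 4-hydroxycyclohex-1-en-1-yl contributes to the number at all, a question that a plain cyclohexenyl ring would address, and whether an amine or a carboxylic acid in its place would keep the number where it stands. The compounds shown also leave open whether the double bond of that ring matters, which a saturated 4-hydroxycyclohexyl ring would test.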